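Triazole-Linked Coumarin Ethers: From Nitro to Nitrile

This account rests on a few compounds, and the source may have more. Where it says the series, first, only, none or still open, it means among the compounds named here.

Compound 2 `O=c1ccc2cc(OCc3cn(-c4ccc([N+](=O)[O-])cc4)nn3)ccc2o1` carries a 4-nitrophenyl group on an aromatic nitrogen of its five-membered ring. In a functional assay on HL-60 cells (Homo sapiens) for cytotoxicity, read by MTT assay, with a stated time of 48 h (on this read-out higher numbers stand for weaker inhibition and lower numbers for stronger inhibition), compound 2 gives 46000 nM. Among the measured compounds shown here, this is the only number in hand: compound 1 `O=c1ccc2cc(OCc3cn(-c4ccccc4Cl)nn3)ccc2o1`, which bears a 2-chlorophenyl group at the same place, is recorded in this assay as "not determined" (no result reported), so compound 2 stands alone and no step between measured compounds can be drawn. Compound 3 `N#Cc1ccccc1-n1cc(COc2ccc3oc(=O)ccc3c2)nn1` differs from compound 2 in one place: 2-cyanophenyl in place of 4-nitrophenyl on an aromatic nitrogen. With a single number to build on, any expectation for compound 3 rests on the weak inhibition shown by compound 2 alone. Given that compound 2 reaches only 46000 nM, compound 3 is expected to remain in the same weak range, with a step of a 1.3-fold higher number from compound 2 to compound 3 (0.12 log units; within the scatter) that may well stay within the scatter rather than beyond it, in either direction. Compound 3 is therefore estimated at 60000 nM in this assay, with a range from 20000 nM to 150000 nM, and a real chance that only a limit is reported.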

Compound 3, half-maximal inhibitory concentration: 52100 nM
The estimate for compound 3 lay 1.2-fold (0.06 log units) above the measured number, within the range that was stated.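

In this assay, exchanging the 4-nitrophenyl group for 2-cyanophenyl on an aromatic nitrogen of the five-membered ring gives a 1.1-fold higher number from compound 2 to compound 3 (0.05 log units; within the scatter), so this position now carries two measured groups whose read-outs cannot be told apart. Among the compounds shown here, that holds although the change removes a group with 2 hydrogen-bond acceptors and a double bond outside aromatic rings and brings in one with 1 hydrogen-bond acceptor and a triple bond, a result that the single number for compound 2 could not show. No independent measurement in hand bears on this result.

Steps involving compound 1, which bears 2-chlorophenyl and has no reported result, cannot be read, so it remains open how a chlorine-bearing phenyl group at this position compares with the two groups measured. Also open, on these data alone, is whether a different group on this nitrogen, such as a phenyl ring bearing an amine or a carboxylic acid, or a longer alkyl chain in place of the phenyl ring, would carry the number beyond the scatter in either direction.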